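Chain shortening from compound 1 to compound 3

The compounds below may be only part of what the source reports. "The series", "measured", "known", "first", "only" and "open" are said of these compounds alone.

Compound 1 `Nc1nc2cc(-c3nn(CCCCCCCCCC(=O)NO)c4ncnc(N)c34)ccc2o1` is the point of departure. In a functional assay on A549 cells (Homo sapiens) for inhibition, read by MTT assay, with a stated time of 72 h (on this read-out higher numbers stand for weaker inhibition and lower numbers for stronger inhibition), compound 1 gives only a limit, > 50000 nM, so its own position is not a number. Compound 2 `Nc1ncnc2c1c(-c1cnc3[nH]ccc3c1)nn2CCCCCCCCCC(=O)NO`, which carries a different aromatic group on the same chain, gives 6550 nM in this assay. Among the measured compounds shown here, the step of an at least 7.6-fold lower number from compound 1 to compound 2 (0.88 log units; beyond the scatter) is the only measured comparison in the set, and it rests on the limit for compound 1 (the limit of > 50000 nM in this assay, at which 1 of the 2 values shown sits). Compound 3 `Nc1nc2cc(-c3nn(CCCCCCCCC(=O)NO)c4ncnc(N)c34)ccc2o1` differs from compound 1 as follows: hydroxycarbamoyl in place of (hydroxycarbamoyl)methyl on a saturated chain carbon, eight bonds along the chain from an aromatic nitrogen. For the measured compounds named here, no measured step touches the length of the chain; the one step recorded concerns the aromatic group and gives no guide here. Compound 3 is therefore expected to sit near compound 1, with a step of a number no higher from compound 1 to compound 3 (the limit leaves the size open) that is not expected to pass beyond the scatter. The estimate for compound 3 in this assay is 50000 nM, with a range from 20000 nM to 150000 nM, and a limit rather than a number is likely again.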

Compound 3, half-maximal inhibitory concentration: 13200 nM
Compound 3: the middle estimate sits 3.8-fold (0.58 log units) above what was measured; measured number outside the range, below it.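

In this assay, among the compounds shown here, the step of an at least 3.7-fold lower number from compound 1 to compound 3 (0.57 log units; beyond the scatter) is the first measured evidence that this chain position responds: hydroxycarbamoyl in place of (hydroxycarbamoyl)methyl, with the aromatic group unchanged, is not a silent change. Compound 1 stands at a limit, so the full size of this step remains undetermined: the limit of > 50000 nM in this assay, at which 1 of the 3 values shown sits.

Alongside the earlier change of aromatic group, the chain is now a second place on compound 1 where a single change yields a number rather than a limit.

The compounds shown give no reading on a chain shorter than that of compound 3, or on a carboxylic acid in place of the hydroxycarbamoyl end group. They also leave open whether the aromatic group of compound 2 and the chain of compound 3 would add up when combined in one molecule.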